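The compounds below may be only part of what the source reports. "The series", "measured", "known", "first", "only" and "open" are said of these compounds alone.

Compound 1 `Cc1ccc(S(=O)(=O)N[C@@H](CC(=O)NC(C)(C)C)C(=O)NCCNS(=O)(=O)c2ccccc2)cc1`: > 11100 nM (a limit)
Compound 2 `Cc1ccc(S(=O)(=O)N[C@@H](CC(=O)NC(C)(C)C)C(=O)NCCNC(=O)c2ccc(F)c(F)c2)cc1`: > 11100 nM (a limit)

Both compounds were tested in an ADME assay on Karpas-1106P cells (Homo sapiens) for cytotoxicity; a higher number here means that more compound is needed for the effect, a lower number that less compound is needed. Compound 2 gives > 11100 nM, which is a limit of the assay and not a number. It shares this position with compound 1, as the record shows: the limit of > 11100 nM in this assay, at which 2 of the 2 values shown sit. Among the compounds with values here, the only measured step is a step that the two limits leave unreadable from compound 1 to compound 2. That step concerns the same end of the molecule as the next change, but it offers no size to carry forward.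

Compound 3 `Cc1ccc(S(=O)(=O)N[C@@H](CC(=O)NC(C)(C)C)C(=O)NCCNC(=O)c2ccccn2)cc1` keeps the core of compound 2 and makes a single change: pyridin-2-yl in place of 3,4-difluorophenyl on a carbonyl carbon. Put simply, pyridin-2-yl replaces 3,4-difluorophenyl on a carbonyl carbon.

With no readable number on either measured compound, the data suggest no direction, and no step beyond the scatter is expected in this assay. The expected outcome is a step that the limit leaves unreadable from compound 2 to compound 3. Most likely, the assay will again report only a limit. The estimated value for compound 3 is 12000 nM, with an expected range of 6000 nM to 30000 nM.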

Compound 3, half-maximal effective concentration: > 11100 nM
Compound 3: a limit, no number; the forecaster's own chance of this, stated with the estimate: 85%; the middle value is on the limit's open side.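

In this assay compound 3 gives > 11100 nM, which is a limit of the assay and not a number. The steps from compound 1 and compound 2 to compound 3 therefore cannot be read: the limit of > 11100 nM in this assay, at which 3 of the 3 values shown sit.

The compounds shown leave open whether phenylsulfonyl, (3,4-difluorophenyl)carbonyl and (pyridin-2-yl)carbonyl differ at all in the amount of compound needed for the effect.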